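Widening the aryl ether in a phenoxyacetic acid series

A few compounds are considered here, and "the series" means these few. Any claim that something is new, unique, unknown or untested is made for them only; others in the source may bear on it.

Within the data shown here, compound 1 `CC(Oc1ccccc1)C(=O)Nc1ccc(OCC(=O)O)c(F)c1` is the only member with a number in a functional assay on CHO cells for agonist activity at Free fatty acid receptor 1 (Homo sapiens), read by FLIPR (on this read-out lower numbers stand for an effect already at smaller amounts and higher numbers for an effect only at larger amounts of compound), where compound 1 gives 135 nM. Compound 2 `CC(Oc1cccc(C(F)(F)F)c1)C(=O)Nc1ccc(OCC(=O)O)c(F)c1` shares the core, and in this assay compound 2 has "not determined" (no result reported). Compound 3 `Cc1ccc(OC(C)C(=O)Nc2ccc(OCC(=O)O)c(F)c2)cc1C` carries 3,4-dimethylphenyl in place of phenyl on an oxygen on a saturated carbon. Among the measured compounds shown here, no step between two measured compounds is available to guide the size of this change, so the expectation rests on compound 1 alone: a modest gain is expected, although a result within the scatter would not surprise. For compound 3 an effect at 70 nM is estimated, within 25 nM to 250 nM, the expected step being a 1.9-fold lower number from compound 1 to compound 3 (0.29 log units; within the scatter).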

Compound 3, half-maximal effective concentration: 133 nM
Compound 3: the middle estimate sits 1.9-fold (0.28 log units) below what was measured, and the stated range covers the measured number.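

Widening the aryl group at this position, on an oxygen on a saturated carbon, now has a first readable step: in this assay, 3,4-dimethylphenyl in place of phenyl gives a 1.0-fold lower number from compound 1 to compound 3 (0.01 log units; within the scatter). The position therefore tolerates this larger group, with the two compounds indistinguishable on this read-out. Nothing available explains this result.

From the compounds shown here alone, it remains open whether a single methyl on the phenyl would behave the same way. The same question stands for a methoxy group or an amine there, or for a longer chain in place of the methyl groups.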